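Hydroxyl Out, Fluorine In: Predicting Maximal Response

The source may report more compounds than this note shows. Statements on the series, on what has been measured and on what is new or still open speak of the compounds shown alone.

Compound 1 `O=C(O)c1cc(-c2cccc(COc3ccc4c(c3)CN(C3CCCC3)C4=O)c2)ccc1O` and compound 2 `O=C(O)c1cc(-c2cccc(COc3ccc4c(=O)n(C5CCCC5)sc4c3)c2)ccc1F` have both been tested in an assay on HEK293 cells for positive allosteric modulation of metabotropic glutamate receptor 2 (Rattus norvegicus), read by thallium flux; on this read-out lower numbers stand for smaller maximal responses and higher numbers for larger maximal responses. In this assay compound 1 gives 90.1%, the top of the two numbers, and compound 2 gives 83.4%, a gap that sits within the usual scatter, so the two behave alike. Compound 3 `O=C(O)c1cc(F)cc(-c2cccc(COc3ccc4c(c3)CN(C3CCCC3)C4=O)c2)c1` has not been measured. It differs from compound 1 by 3-carboxy-5-fluorophenyl in place of 3-carboxy-4-hydroxyphenyl on an aromatic carbon. Among the compounds with values here, no measured pair shows what this change does, so no shift beyond the scatter is expected in this assay. The expected step is a number 4.1 percentage points lower from compound 1 to compound 3 (within the scatter). Compound 3 is expected to reach 86%, between 70% and 100%.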

Compound 3, largest response reached (reported as percent of maximum), in percent of the reference or control that the assay uses: 80.8%
The estimate for compound 3 lay 5.2 percentage points above the measured number, and the stated range covers the measured number.
By their numbers in this assay, from the lowest: compounds 3, 2 and 1 (each within the scatter of the next).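

Within the data shown here, the swap of 3-carboxy-4-hydroxyphenyl for 3-carboxy-5-fluorophenyl gives the first direct reading at this position: this assay shows a number 9.3 percentage points lower from compound 1 to compound 3 (within the scatter). The maximal response therefore holds up within the scatter when this ring loses its hydroxyl and gains a fluorine. Nothing available explains this outcome.

As far as these compounds go, because the hydroxyl leaves and the fluorine enters in one step, the separate contribution of each remains open. Also open, from the compounds shown here alone, is how a methoxy group or an amine on this ring would fare.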